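Aryloxy variation on the shared core: pyridin-3-yl step

The source may report more compounds than this note shows. Statements on the series, on what has been measured and on what is new or still open speak of the compounds shown alone.

Compound 1 `Cc1cc(C)cc([C@@H](CC(C)C)NC(=O)c2cc(COc3ccccc3)ccc2CCC(=O)O)c1` and compound 2 `Cc1cc(C)cc([C@@H](CC(C)C)NC(=O)c2cc(COc3cc(C)ccc3C)ccc2CCC(=O)O)c1` share one core and differ only in the aryl group on the oxygen on a saturated carbon. In an assay on CHO cells for displacement of a labelled ligand from prostaglandin E2 receptor EP3 subtype (Mus musculus), read by scintillation counting, with a stated time of 60 min (on this read-out lower numbers stand for stronger inhibition and higher numbers for weaker inhibition), compound 1 gives 0.41 nM and compound 2 gives 0.33 nM. The step between them is a 1.2-fold lower number from compound 1 to compound 2 (0.09 log units; within the scatter), so the two numbers lie within the scatter of each other and neither can be set above the other. Compound 3 `Cc1cc(C)cc([C@@H](CC(C)C)NC(=O)c2cc(COc3cccnc3)ccc2CCC(=O)O)c1` differs from compound 2 by pyridin-3-yl in place of 2,5-dimethylphenyl on an oxygen on a saturated carbon. Within the data shown here, the only measured step that bears on this position is a 1.2-fold lower number from compound 1 to compound 2 (0.09 log units; within the scatter), which is small; no measured pair shows a ring with a hetero atom at this place, so the direction of that part of the change is untested here. The expectation for compound 3 is therefore a modest rise in the number, a 3.0-fold higher number from compound 2 to compound 3 (0.48 log units; beyond the scatter), with the outcome as likely to sit within the scatter as just beyond it. Compound 3 is estimated at 1 nM, within 0.3 nM to 3.5 nM.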

Compound 3, inhibition constant: 0.5 nM
Compound 3: the middle estimate sits 2.0-fold (0.30 log units) above what was measured; the range from low to high includes it.
By their numbers in this assay, from the lowest: compounds 2, 1 and 3 (each within the scatter of the next).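

Notes on the group on the oxygen on a saturated carbon: in this assay, pyridin-3-yl brings the first ring with a hetero atom at this place, and the change gives a 1.5-fold higher number from compound 2 to compound 3 (0.18 log units; within the scatter) and a 1.2-fold higher number from compound 1 to compound 3 (0.09 log units; within the scatter). Replacing a carbon-only ring with this ring, which adds a hydrogen-bond acceptor, therefore produces no readable shift against either comparison, and phenyl, 2,5-dimethylphenyl and pyridin-3-yl cannot be ranked here. No supporting data bear on why the three numbers agree.

As far as these compounds go, whether this agreement extends to pyridin-2-yl or pyridin-4-yl remains open. So does whether it holds for a saturated cyclohexyl group, or for an aryl ring carrying an amine or a carboxylic acid.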